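Arylamino linker on a benzothiophene ketone: an estimate

The source may hold more compounds than are shown below. What is called first, only, known or untested is meant among the compounds shown, and "the series" means these compounds.

Compound 1 `COc1cc(C(=O)c2sc3ccccc3c2-c2ccc(F)cc2)cc(OC)c1OC`: 3200 nM
Compound 2 `COc1cc(C(=O)c2sc3ccccc3c2-c2ccc(C)cc2)cc(OC)c1OC`: 7800 nM
Compound 3 `COc1cc(C(=O)c2sc3ccccc3c2-c2ccc(SC)cc2)cc(OC)c1OC`: 5400 nM

In a functional assay on A549 cells (Homo sapiens) for antiproliferative activity, read by MTT assay, with a stated time of 72 h (on this read-out higher numbers stand for weaker inhibition and lower numbers for stronger inhibition), compound 1 gives the lowest number of the three, with compound 3 nearest and compound 2 furthest. The step of a 2.4-fold higher number from compound 1 to compound 2 (0.39 log units; beyond the scatter) is modest but beyond the scatter, whereas a 1.7-fold higher number from compound 1 to compound 3 (0.23 log units; within the scatter) and a 1.4-fold lower number from compound 2 to compound 3 (0.16 log units; within the scatter) stay within it.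

Compound 4 `COc1cc(C(=O)c2sc3ccccc3c2Nc2ccc(C)cc2)cc(OC)c1OC` is not yet measured. It differs from compound 1 by (4-methylphenyl)amino in place of 4-fluorophenyl on an aromatic carbon. Going by the values given here, only the step from compound 1 to compound 2 bears on this change, since it also brings a methyl onto the outer ring; the nitrogen link that enters has no counterpart among the measured compounds. The expectation is therefore a modest rise in the number, estimated as a 1.7-fold higher number from compound 1 to compound 4 (0.24 log units; within the scatter), with wide uncertainty because of the untested linker. For compound 4 the estimate in this assay is 5500 nM, expected to fall between 1500 nM and 20000 nM.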

Compound 4, half-maximal inhibitory concentration: 2600 nM
The estimate for compound 4 lay 2.1-fold (0.33 log units) above the measured number, within the range that was stated.
By their numbers in this assay, from the lowest: compounds 4, 1, 3 and 2 (each within the scatter of the next, the first and the last beyond it).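

The clearest reading comes from the pair that shares the same outer ring: in this assay, (4-methylphenyl)amino in place of 4-methylphenyl gives a 3.0-fold lower number from compound 2 to compound 4 (0.48 log units; beyond the scatter), so at this position the nitrogen link goes with a lower number, not a loss of activity. The comparison with the methylsulfanyl compound also gives a 2.1-fold lower number from compound 3 to compound 4 (0.32 log units; beyond the scatter), although that step changes the outer-ring substituent as well as the link. By contrast, a 1.2-fold lower number from compound 1 to compound 4 (0.09 log units; within the scatter) leaves that pair without an order, so the amino-linked compound cannot be placed ahead of the fluoro compound.

No independent evidence bearing on this result is available. The compounds shown leave open how an oxygen or methylene link would compare at this position, and whether fluoro or methylsulfanyl on the outer ring of the amino-linked compound would give a different number.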